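The source may hold more compounds than are shown below. What is called first, only, known or untested is meant among the compounds shown, and "the series" means these compounds.

Of the compounds shown here, two have been measured in an assay on Expi293F cells for binding affinity to adenosine receptor A2b (Homo sapiens), read by surface plasmon resonance; a higher number here means weaker binding, a lower number tighter binding. Compound 1 `CS(=O)(=O)c1ccc(C(=O)Nc2cccc(Cl)c2)cc1` gives 19300 nM in this assay. Compound 2 `Nc1nsc(-c2ccccc2)n1` gives 108000 nM in this assay, which is the highest of the two numbers and therefore the weakest binding seen so far; the nearest number is that of compound 1, and the gap between them is beyond the usual scatter of repeated measurements.

The step of interest leads from compound 2 to compound 3 `Nc1nsc(-c2ccc(Cl)cc2)n1`, which has not yet been measured in this assay. The change is small: chloro in place of hydrogen on an aromatic carbon. Going by the values given here, no other pair of measured compounds shows the effect of adding a chloro group in this way, so there is no directly comparable step to lean on.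

With only the two numbers above as background, the expected step from compound 2 to compound 3 is a 2.2-fold lower number from compound 2 to compound 3 (0.33 log units; beyond the scatter), a modest move toward tighter binding that may well sit within the scatter. For compound 3 the estimated value in this assay is 50000 nM, with a plausible range from 15000 nM to 200000 nM.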

Compound 3, dissociation constant: 45000 nM
Beside the measured number, compound 3's estimate is 1.1-fold (0.05 log units) above it; the measured number falls inside the stated range.
By their numbers in this assay, from the lowest: compound 1; then compound 3; then compound 2.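

In this assay, chloro in place of hydrogen on an aromatic carbon, para to a group of 6 heavy atoms, gives a 2.4-fold lower number from compound 2 to compound 3 (0.38 log units; beyond the scatter), a modest step toward tighter binding. Going by these compounds alone, because compound 2 and compound 3 differ in this one place only, this is the first reading of what a single change does here; compound 1 differs from both in too many places to offer one. The position accepts a chloro group with a small gain in binding, but the data give only the size and direction of that gain, and nothing measured here bears on the reason for it.

Still open, going by these compounds, is whether this gain is particular to chloro, or whether a fluoro, methyl or methoxy group at the same place would give a similar, larger or opposite step. It is also unclear whether a chloro group on another carbon of the same six-membered ring would do the same, and whether a larger group, such as a carboxylic acid or a longer chain, would fit at this position.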